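The compounds below may be only part of what the source reports. "The series", "measured", "known", "first", "only" and "open" are said of these compounds alone.

Series notes. Compound 1 `CC(=O)c1ccc2c(c1)nc(-c1ccccc1)n2C1CCCCC1` and compound 2 `COc1ccc(-c2nc3cc(C(C)=O)ccc3n2C2CCCCC2)cc1` share a core; compound 2 carries methoxy in place of hydrogen on an aromatic carbon. In an ADME assay on BHK-21 cells (Mesocricetus auratus) for cytotoxicity, read by MTT assay (on this read-out higher numbers stand for lower toxicity in this test and lower numbers for higher toxicity in this test), compound 1 gives 100000 nM. For compound 2 the value in this assay is a limit, > 100000 nM. Within the data shown here, the step of a number no lower from compound 1 to compound 2 (the limit leaves the size open) is therefore open in size; the only evidence bearing on it is the limit of > 100000 nM in this assay, at which 1 of the 3 values shown sits.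

Compound 3 `COc1ccc(-c2nc3cc(/C(C)=N/NC(N)=O)ccc3n2C2CCCCC2)cc1` has a different core; the difference between the two cores is not broken down here. In this assay compound 3 shows "not determined" (no result reported).

Compound 4 `COc1ccc(-c2nc3cc(/C(C)=N/NC(N)=O)ccc3n2C2CCCCC2)c(OC)c1` is not yet measured and differs from compound 3 by methoxy in place of hydrogen on an aromatic carbon. This is the same kind of change as from compound 1 to compound 2, but the surroundings differ: in compound 2 the entering group sits para to a large group, in compound 4 it sits ortho to a large group and meta to a methoxy group.

For compound 4 in this assay a step of roughly the size seen in a number no lower from compound 1 to compound 2 (the limit leaves the size open) is expected, resting on compound 1 at 100000 nM. Compound 2 contributes only a limit in this assay. Compound 4 is therefore expected near 100000 nM, within 40000 nM to 200000 nM, with a real chance that only a limit is reported.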

Compound 4, half-maximal cytotoxic concentration: 19000 nM
Compound 4: middle estimate off by 5.3-fold (0.72 log units), on the high side, outside the stated range (below it).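

No new step can be read between compound 3 and compound 4: in this assay compound 3 shows "not determined" (no result reported), while compound 4 gives 19000 nM. The compounds shown leave open how much of the value of compound 4 belongs to the change from 4-methoxyphenyl to 2,4-dimethoxyphenyl and how much to its core.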